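Aryl exchange on the ring amine nitrogen: working notes

This account rests on a few compounds, and the source may have more. Where it says the series, first, only, none or still open, it means among the compounds named here.

Measured so far:
compound 1 `Nc1scc(CN2CCN(c3cccc(Cl)c3Cl)CC2)c1C(=O)c1ccc(Cl)cc1` — -77%
compound 2 `Nc1scc(CN2CCN(c3ccc(OC(F)(F)F)cc3)CC2)c1C(=O)c1ccc(Cl)cc1` — -74%

In a functional assay on CHO cells with adenosine receptor A1 (Homo sapiens) as the target, read by cAMP accumulation and immunoassay, with a stated time of 6 min, tested at 10 uM (a higher number here means a weaker effect of the compound at the concentration tested, a lower number a stronger effect), compound 1 gives -77% and compound 2 gives -74%. Compound 2 thus holds the highest of the two numbers, with compound 1 nearest, but the two lie within the scatter of each other. For the measured compounds named here, the single measured step is a number 3 percentage points higher from compound 1 to compound 2 (within the scatter), an exchange of one aryl group for another on the amine nitrogen in the ring, and it does not leave the scatter.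

Compound 3 `Nc1scc(CN2CCN(c3cccc4ccccc34)CC2)c1C(=O)c1ccc(Cl)cc1` has not yet been run in this assay. It differs from compound 2 by naphthalen-1-yl in place of 4-(trifluoromethoxy)phenyl on an amine nitrogen in a ring. Going by the values given here, this is again an aryl exchange at the same ring nitrogen, so the one measured exchange of that kind bears on it directly. Among the compounds with values here, with only that step to go by, no movement beyond the scatter is expected, and the estimated step is a number 1 percentage points lower from compound 2 to compound 3 (within the scatter). Compound 3 is therefore expected to give about -75%, with a range from -88% to -58%.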

Compound 3, a percentage reported as activity, at one concentration (the size of the read-out at that concentration, not a potency): -21%
Compound 3: the middle estimate sits 54 percentage points below what was measured; measured number above the stated range.
By their numbers in this assay, from the lowest: compounds 1 and 2 (each within the scatter of the next); then compound 3.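

Naphthalen-1-yl on the ring amine nitrogen brings a number 53 percentage points higher from compound 2 to compound 3 (beyond the scatter) and also a number 56 percentage points higher from compound 1 to compound 3 (beyond the scatter) in this assay, so this position is not indifferent to the aryl group it carries, as the step between compound 1 and compound 2 alone had suggested. Among these three compounds, 2,3-dichlorophenyl and 4-(trifluoromethoxy)phenyl, each with one aromatic ring, stay within the scatter of each other, while naphthalen-1-yl, with two aromatic rings, gives a clearly weaker effect. No supporting measurement is available to explain this weakening.

On these data alone, whether the weaker effect follows the second aromatic ring or the particular way naphthalene is attached remains open. Unsubstituted phenyl, naphthalen-2-yl or quinolinyl on the same nitrogen would help separate these two readings.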